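This account rests on a few compounds, and the source may have more. Where it says the series, first, only, none or still open, it means among the compounds named here.

Among the compounds with values here, compound 2 `COc1ccc(-c2nc(C(=O)/C=C\Nc3ccc(Cl)cc3)c3ccccn23)cc1` is the stronger of the two compounds measured so far. In a functional assay on B16-F10 cells (Mus musculus) for cytotoxicity, read by MTT assay, with a stated time of 48 h (on this read-out higher numbers stand for weaker inhibition and lower numbers for stronger inhibition), compound 2 gives 1240 nM, whereas compound 1 `COc1ccc(N/C=C\C(=O)c2nc(-c3ccc(F)cc3)n3ccccc23)cc1` gives 2560 nM, a gap that lies beyond the usual scatter. The next compound, compound 3 `COc1ccc(N/C=C\C(=O)c2nc(-c3ccc(OC)cc3)n3ccccc23)cc1`, has not yet been tested. It differs from compound 2 in one place: methoxy in place of chloro on an aromatic carbon. Within the data shown here, no measured pair shows this exact change on this scaffold, so there is no step to lean on. With only two measured points and no comparable exchange among them, compound 3 is expected to land close to compound 2, with a step of a 1.5-fold higher number from compound 2 to compound 3 (0.16 log units; within the scatter) that does not exceed the scatter in either direction. On that basis compound 3 is estimated at 1800 nM in this assay, within a range from 700 nM to 4500 nM.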

Compound 3, half-maximal inhibitory concentration: 2120 nM
Compound 3: middle estimate off by 1.2-fold (0.07 log units), on the low side; the range from low to high includes it.
By their numbers in this assay, from the lowest: compounds 2, 3 and 1 (each within the scatter of the next, the first and the last beyond it).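

In this assay, methoxy in place of chloro on the (4-chlorophenyl)amino group gives a 1.7-fold higher number from compound 2 to compound 3 (0.23 log units; within the scatter), and exchanging fluoro for methoxy gives a 1.2-fold lower number from compound 1 to compound 3 (0.08 log units; within the scatter). Both steps lie within the scatter, so methoxy can stand in place of either halogen, each at its own place on the core, with no readable change in this cytotoxicity read-out, something the two earlier compounds could not show on their own. Nothing at hand gives a reason for this result.

From the compounds shown here alone, it remains open whether an amine or a carboxylic acid at these same aromatic carbons would move the number beyond the scatter. Going by these compounds, it is also open whether chloro and fluoro would behave alike if each were exchanged at the other's place.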